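The source may report more compounds than this note shows. Statements on the series, on what has been measured and on what is new or still open speak of the compounds shown alone.

Of the compounds shown here, two of the shared core have been measured in a functional assay on PC-3 cells (Homo sapiens) for antiproliferative activity, read by MTT assay; a higher number here means a weaker inhibitor, a lower number a stronger inhibitor. Compound 1 `Cn1c(=O)c(=O)n(C2CCCC2)c2nc(N/N=C/c3ccccc3)ncc21` gives 48200 nM in this assay, and compound 2 `Cn1c(=O)c(=O)n(C2CCCC2)c2nc(N/N=C/c3ccc(Cl)cc3)ncc21` gives 8420 nM. Among the compounds with values here, the single step between them, a 5.7-fold lower number from compound 1 to compound 2 (0.76 log units; beyond the scatter), is the only change so far on the ring that hangs from the carbon with a double bond to nitrogen. Within the data shown here, on these two numbers compound 2 stands lowest, with compound 1 as its only neighbour.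

Compound 3 `Cn1c(=O)c(=O)n(C2CCCC2)c2nc(N/N=C/c3ccc(O)c(F)c3)ncc21` has not yet been measured. It differs from compound 2 in one place: 3-fluoro-4-hydroxyphenyl in place of 4-chlorophenyl on a carbon with a double bond to nitrogen. This change removes the very chloro whose arrival produced the step from compound 1 to compound 2, and puts a fluorine and a hydroxyl on the ring instead. Among the measured compounds shown here, no measured step shows what a hydroxyl or a fluorine does here, so the only guidance is that losing the chloro could move the number back toward that of compound 1. The step is therefore estimated as a 2.4-fold higher number from compound 2 to compound 3 (0.38 log units; beyond the scatter), a rise that falls short of the full return. Compound 3 is estimated at 20000 nM, within a range from 6000 nM to 60000 nM.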

Compound 3, half-maximal inhibitory concentration: 85200 nM
Estimate against measurement, compound 3: 4.3-fold (0.63 log units) below; measured number above the stated range.
By their numbers in this assay, from the lowest: compound 2; then compounds 1 and 3 (each within the scatter of the next).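

In this assay, the change to 3-fluoro-4-hydroxyphenyl on a carbon with a double bond to nitrogen gives a 10-fold higher number from compound 2 to compound 3 (1.01 log units; beyond the scatter), a large step showing that the low number of compound 2 does not survive this exchange of ring. Set against the plain phenyl, the result is a 1.8-fold higher number from compound 1 to compound 3 (0.25 log units; within the scatter), so compound 1 and compound 3 cannot be told apart here, and among the three rings only 4-chlorophenyl stands apart, with compound 2 at 8420 nM. No measurement at hand bears on why the numbers fall as they do.

As far as these compounds go, the fluorine and the hydroxyl enter together, so what each does alone at this position stays open, as does whether either of them, on its own, would leave the number where the phenyl ring of compound 1 puts it. From the compounds shown here alone, it is also open whether the low number belongs to chloro in particular or would extend to another group in its place, such as bromo, methoxy or an amine on the same ring.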